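A Hydroxy Group on the Ethyl Amide Chain

The source may report more compounds than this note shows. Statements on the series, on what has been measured and on what is new or still open speak of the compounds shown alone.

Compound 3 `CCNC(=O)c1c(NO)cc(-c2ccccc2)oc1=O` carries an ethyl group on the amide-type nitrogen of the shared core. In an ADME assay on Huh-7 cells (Homo sapiens) for cytotoxicity, read by a luciferase reporter and WST assay, with a stated time of 3 days (a higher number here means that more compound is tolerated, a lower number that less compound is tolerated), compound 3 gives > 20000 nM, which is a limit of the assay and not a number. In this assay compound 1 `COc1ccc(NC(=O)c2c(NO)cc(-c3ccccc3)oc2=O)cc1` gives > 20000 nM, also a limit. In this assay compound 2 `Cc1ccccc1NC(=O)c1c(NO)cc(-c2ccccc2)oc1=O` gives > 20000 nM, again a limit. All three values sit at the limit of > 20000 nM in this assay, at which 3 of the 3 values shown sit, so a step that the two limits leave unreadable from compound 1 to compound 2, a step that the two limits leave unreadable from compound 1 to compound 3 and a step that the two limits leave unreadable from compound 2 to compound 3 carry no readable size. Compound 4 `O=C(NCCO)c1c(NO)cc(-c2ccccc2)oc1=O` differs from compound 3 by hydroxy in place of hydrogen on a saturated chain carbon, two bonds along the chain from an amide-type nitrogen. Going by the values given here, no measured step bears on this change. Compound 4 is therefore expected to give about 30000 nM in this assay, between 10000 nM and 100000 nM. The expected step is a step that the limit leaves unreadable from compound 3 to compound 4, not beyond the scatter.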

Compound 4, half-maximal cytotoxic concentration: > 20000 nM
Compound 4 was reported as a limit; the forecaster's own chance of this, stated with the estimate: 85%; the middle value lies beyond the limit too.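

Going by these compounds alone, compound 4 is also reported as a limit, so no step between compound 1, compound 2, compound 3 and compound 4 can be read: (the limit of > 20000 nM in this assay, at which 4 of the 4 values shown sit). The compounds shown leave open whether any change on the amide-type nitrogen shifts the read-out in this assay at all.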